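The source may hold more compounds than are shown below. What is called first, only, known or untested is meant among the compounds shown, and "the series" means these compounds.

Working notes on the series.

Compound 1 `COc1cc2cc(Oc3ccc(NC(=O)Nc4cccc(C(F)(F)F)c4)cc3)c(C)nc2cc1OC` sets the starting point: in a functional assay on SK-MEL-5 cells (Homo sapiens) for inhibition, read by sulforhodamine B assay, with a stated time of 48 h (on this read-out higher numbers stand for weaker inhibition of growth and lower numbers for stronger inhibition of growth), compound 1 gives 2660 nM. Compound 2 `COc1cc2cc(Oc3ccc(NC(=O)Nc4ccc(Cl)c(C(F)(F)F)c4)cc3)c(C)nc2cc1OC` carries an added chloro on the aromatic ring bearing the trifluoromethyl group, and in this assay compound 2 gives 2170 nM. Among the measured compounds shown here, the step of a 1.2-fold lower number from compound 1 to compound 2 (0.09 log units; within the scatter) is the only measured step in the set, and it does not separate the two compounds. For the measured compounds named here, compound 2 thus stands at a number indistinguishable from that of compound 1 on the numbers so far; no ordering between them is supported.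

Compound 3 `COc1cc2cc(Oc3ccc(NC(=O)Nc4ccc(Cl)c(Cl)c4)cc3)c(C)nc2cc1OC` is the next member. The change from compound 2 is chloro in place of trifluoromethyl on an aromatic carbon. Going by the values given here, no measured step covers this replacement: the one known step, a 1.2-fold lower number from compound 1 to compound 2 (0.09 log units; within the scatter), concerns the addition of chloro at a different aromatic carbon and was within the scatter, and it says nothing about exchanging trifluoromethyl for chloro. Without a precedent, the expectation in this assay is no step beyond the scatter, with a wide band of uncertainty. The expected step is a 1.2-fold higher number from compound 2 to compound 3 (0.06 log units; within the scatter). For compound 3 the estimate in this assay is 2500 nM, with a range from 800 nM to 8000 nM.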

Compound 3, concentration for total growth inhibition: 8090 nM
Compound 3: the middle estimate sits 3.2-fold (0.51 log units) below what was measured; measured number above the stated range.
By their numbers in this assay, from the lowest: compounds 2 and 1 (each within the scatter of the next); then compound 3.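

In this assay, among the compounds shown here, the exchange on the aromatic carbon ortho to a chloro group gives a 3.7-fold higher number from compound 2 to compound 3 (0.57 log units; beyond the scatter), the first step beyond the scatter. This position therefore responds to the group it carries, which the earlier step, a 1.2-fold lower number from compound 1 to compound 2 (0.09 log units; within the scatter), could not show because it concerned a different aromatic carbon and stayed within the scatter. The wider change from 3-(trifluoromethyl)phenyl to 3,4-dichlorophenyl gives a 3.0-fold higher number from compound 1 to compound 3 (0.48 log units; beyond the scatter), so compound 3 is the weakest growth inhibitor of the three, while compound 1 and compound 2, which both keep trifluoromethyl, cannot be separated. Nothing available explains why the number rises with this exchange.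

The compounds shown leave open whether a nitrile or an amine at this position would match compound 2 or compound 3, since only trifluoromethyl and chloro are compared there. They also leave open whether the exchange of trifluoromethyl for chloro gives a step of similar size when the neighbouring chloro is replaced by a methoxy group.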